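Urea in place of chloroacetamide on a sulfonate ester core

The source may report more compounds than this note shows. Statements on the series, on what has been measured and on what is new or still open speak of the compounds shown alone.

Measured compounds:
compound 1 `CC(C)c1ccccc1OS(=O)(=O)c1ccc(NC(=O)C(C)(C)C)cc1` with 15000 nM in a functional assay on HT-29 cells (Homo sapiens) for antiproliferative activity, read by sulforhodamine B assay, with a stated time of 48 h; on this read-out lower numbers stand for stronger inhibition and higher numbers for weaker inhibition
compound 2 `CC(C)c1ccccc1OS(=O)(=O)c1ccc(NC(=O)CCl)cc1` with 5600 nM in this assay

Within the data shown here, compound 2 stands at the lowest of the two numbers; its only neighbour is compound 1, and the step between them is a 2.7-fold lower number from compound 1 to compound 2 (0.43 log units; beyond the scatter), a modest step beyond the scatter.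

Compound 3 `CC(C)c1ccccc1OS(=O)(=O)c1ccc(NC(=O)NCCCCl)cc1` has not yet been measured in this assay. It differs from compound 2 in one place: (3-chloropropyl)amino in place of chloromethyl on a carbonyl carbon. Among the measured compounds shown here, the sole measured step, a 2.7-fold lower number from compound 1 to compound 2 (0.43 log units; beyond the scatter), exchanges a tert-butyl for a chloromethyl on the same carbonyl carbon; it is of limited bearing, since the present change instead puts a (3-chloropropyl)amino group there and turns the amide into a urea. With so little to go on, a modest step toward a higher number is expected, as a 1.8-fold higher number from compound 2 to compound 3 (0.25 log units; within the scatter). Compound 3 is therefore estimated at 10000 nM, with a range from 3000 nM to 35000 nM.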

Compound 3, half-maximal inhibitory concentration: 6900 nM
Beside the measured number, compound 3's estimate is 1.4-fold (0.16 log units) above it; the measured number falls inside the stated range.
By their numbers in this assay, from the lowest: compounds 2 and 3 (each within the scatter of the next); then compound 1.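

In this assay, a (3-chloropropyl)amino group on the carbonyl carbon and a chloromethyl group there cannot be told apart, with a 1.2-fold higher number from compound 2 to compound 3 (0.09 log units; within the scatter), so turning the amide into a urea and lengthening the chain leaves the reading within the scatter. Measured against the tert-butyl group, the new group gives a 2.2-fold lower number from compound 1 to compound 3 (0.34 log units; beyond the scatter), so among the three compounds both chlorine-bearing groups lie beyond the scatter of tert-butyl, by a modest margin. Nothing available explains these readings.

The compounds shown leave open whether the chlorine itself counts, which a plain propylamino group on the same carbonyl carbon would test. They also leave open how a shorter or longer chloroalkyl chain would read, or a hydroxyl or an amine in place of that chlorine.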